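Swapping the Sulfonamide Substituent in a Kinase Inhibitor Series

This account rests on a few compounds, and the source may have more. Where it says the series, first, only, none or still open, it means among the compounds named here.

Compound 2 `Cn1ccc2ccc(-c3cc(Nc4ccccc4S(=O)(=O)N4CCOCC4)cc4nccnc34)cc21` is the reference point here. In an assay on lysate for inhibition of 6-phosphofructo-2-kinase/fructose-2,6-bisphosphatase 3 (Homo sapiens), with stated times of 0.5 min and 45 min (on this read-out higher numbers stand for weaker inhibition and lower numbers for stronger inhibition), compound 2 gives 2640 nM, the only numerical result among the two compounds tested. Compound 1 `CNS(=O)(=O)c1ccccc1Nc1cc(-c2ccc3ccn(C)c3c2)c2nccnc2c1` carries a methylamino group on the sulfonyl sulfur instead. In this assay compound 1 reaches only the assay limit of > 100000 nM, a limit rather than a number, as recorded in the limit of > 100000 nM in this assay, at which 1 of the 2 values shown sits. The change between them, an at least 37-fold lower number from compound 1 to compound 2 (1.57 log units; beyond the scatter), shows that replacing the methylamino group with morpholin-4-yl strengthened inhibition considerably.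

Compound 3 `CN1CCC(NS(=O)(=O)c2ccccc2Nc2cc(-c3ccc4ccn(C)c4c3)c3nccnc3c2)C1` has not yet been tested. Its difference from compound 2 is (1-methylpyrrolidin-3-yl)amino in place of morpholin-4-yl on a sulfonyl sulfur. This change brings back a hydrogen-bond donor on the sulfonyl sulfur, as in compound 1, but with a larger ring bearing a second nitrogen. Because the step of an at least 37-fold lower number from compound 1 to compound 2 (1.57 log units; beyond the scatter) was large when the donor was removed, a move back toward a donor-bearing sulfonamide is expected to weaken inhibition. Compound 3 is therefore expected to give 12000 nM in this assay, within a range of 2500 nM to 100000 nM, corresponding to an expected step of a 4.5-fold higher number from compound 2 to compound 3 (0.66 log units; beyond the scatter).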

Compound 3, half-maximal inhibitory concentration: 3160 nM
Compound 3: the middle estimate sits 3.8-fold (0.58 log units) above what was measured; the measured number falls inside the stated range.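

In this assay the exchange of morpholin-4-yl for (1-methylpyrrolidin-3-yl)amino on the sulfonyl sulfur gives a 1.2-fold higher number from compound 2 to compound 3 (0.08 log units; within the scatter), so these two quite different groups cannot be told apart here, although the first has no hydrogen-bond donor and the second has one. A hydrogen-bond donor at this place therefore does not by itself go with weak inhibition: with that donor kept, putting 1-methylpyrrolidin-3-yl in place of methyl on the sulfonamide nitrogen gives an at least 31-fold lower number from compound 1 to compound 3 (1.50 log units; beyond the scatter). That step can be stated only as a bound because compound 1 stands at a limit of the assay and not at a number: the limit of > 100000 nM in this assay, at which 1 of the 3 values shown sits.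

The compounds shown do not separate the ring from its nitrogen, so it remains open whether a cyclopentylamino group or a longer chain such as n-butylamino on the sulfonyl sulfur would match compound 3 or fall back toward compound 1. On these data alone, it also remains open whether a group carrying a carboxylic acid would be tolerated at this place, and whether any group here can go clearly beyond compound 2 and compound 3.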